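Selenol to methylsulfanyl on the fused core: expectation

A few compounds are considered here, and "the series" means these few. Any claim that something is new, unique, unknown or untested is made for them only; others in the source may bear on it.

Two compounds of this series have numbers in a functional assay on HT-29 cells (Homo sapiens) for cytotoxicity, read by MTT assay, with a stated time of 72 h; on this read-out higher numbers stand for weaker inhibition of growth and lower numbers for stronger inhibition of growth. Compound 1 `COc1ccc(CNc2nc(SC)nc3ccccc23)cc1` gives 70200 nM in this assay. Compound 2 `[SeH]c1nc(NCc2ccccc2)c2ccccc2n1` gives 62200 nM in this assay, the lowest of the two numbers shown; its nearest neighbour is compound 1, and the gap between them falls within the scatter, so the two values cannot be ordered against each other. Both point to weak inhibition of growth.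

Compound 3 `CSc1nc(NCc2ccccc2)c2ccccc2n1` is the next compound, not yet measured in this assay. It differs from compound 2 in one place: a group of 2 heavy atoms (1 carbon, 1 sulfur; no ring) in place of one selenium atom, on an aromatic carbon. The change sits on an aromatic carbon of a six-membered aromatic ring with two nitrogen atoms, between two ring nitrogen atoms, para to a fused ring. Within the data shown here, no measured pair shows this change, so its size is not known from data.

Compound 1 also carries methylsulfanyl at this position and gives a number close to compound 2. The step from compound 2 to compound 3 is therefore expected to be a 1.0-fold higher number from compound 2 to compound 3 (0.02 log units; within the scatter), none beyond the scatter. Compound 3 is estimated at 65000 nM, with a range from 25000 nM to 170000 nM.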

Compound 3, concentration for 50% growth inhibition: 36500 nM
Compound 3: middle estimate off by 1.8-fold (0.25 log units), on the high side; the range from low to high includes it.
By their numbers in this assay, from the lowest: compounds 3, 2 and 1 (each within the scatter of the next).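

In this assay, the exchange of one selenium atom for methylsulfanyl on the aromatic carbon between two ring nitrogen atoms now has a measured size: a 1.7-fold lower number from compound 2 to compound 3 (0.23 log units; within the scatter). This step stays within the scatter, as does the step at the other site, hydrogen in place of methoxy on an aromatic carbon, a 1.9-fold lower number from compound 1 to compound 3 (0.28 log units; within the scatter), so neither exchange can be told apart from repeat variation and the three compounds cannot be ordered. No data on these compounds offer an explanation for the values at either site.

Still open, from the compounds shown here alone, is whether any group at the position between the two ring nitrogen atoms moves the number beyond the scatter, for instance an amine, a free thiol or a longer alkylsulfanyl chain such as butylsulfanyl. Also open, going by these compounds, is whether a carboxylic acid or a halogen in place of the methoxy group of compound 1 would do so, and whether the close grouping of these three compounds holds in other cell lines.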